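The compounds below may be only part of what the source reports. "The series", "measured", "known", "first", "only" and "open" are said of these compounds alone.

In an ADME assay on HepG2 cells (Homo sapiens) for cytotoxicity, read by MTT assay, with a stated time of 72 h (a higher number here means that more compound is tolerated, a lower number that less compound is tolerated), compound 3 (`ClC(Cl)(Cl)c1ncc2ccccc2n1`) gives 61000 nM as the lowest number in the series, and compound 1 (`ClC(Cl)(Cl)c1nccc2ccccc12`) gives 180000 nM on the more tolerated side, a gap beyond the scatter. Compound 2 (`ClC(Cl)(Cl)c1ncnc2ccccc12`) reads > 500000 nM as a limit of the assay and not a number. Compound 4 (`Cc1ncc2ccccc2n1`) carries methyl in place of trichloromethyl on an aromatic carbon, between two ring nitrogen atoms (methyl in place of trichloromethyl on an aromatic carbon). For the measured compounds named here, no measured pair shows this change, so the expectation rests on compound 3 at 61000 nM sitting at the low end of the values. An upward step beyond the scatter is expected in this assay (a 3.6-fold higher number from compound 3 to compound 4 (0.56 log units; beyond the scatter)). For compound 4 the estimated value is 220000 nM with an expected range from 90000 nM to 500000 nM in this read-out.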

Compound 4, half-maximal cytotoxic concentration: 350000 nM
Estimate against measurement, compound 4: 1.6-fold (0.20 log units) below, and the stated range covers the measured number.
By their numbers in this assay, from the lowest: compound 3; then compounds 1 and 4 (each within the scatter of the next). At a limit, above all of these: compound 2.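

In this assay the position between two ring nitrogen atoms now has a measured change, with methyl in place of trichloromethyl giving a 5.7-fold higher number from compound 3 to compound 4 (0.76 log units; beyond the scatter) on this core. On this core, then, the lower number goes with trichloromethyl and the more tolerated side with methyl, though this rests on a single pair. Nothing given here bears on the cause of this step. As far as these compounds go, whether an amine, a carboxylic acid or a longer chain at this position would follow methyl stays open. From the compounds shown here alone, the same change on the cores of compound 1 and compound 2 also stays open.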